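This account rests on a few compounds, and the source may have more. Where it says the series, first, only, none or still open, it means among the compounds named here.

Measured compounds:

- Compound 1, `Nc1scc(CN2CCN(c3ccc(C(F)(F)F)cc3)CC2)c1C(=O)c1cccc(C(F)(F)F)c1`: -12%
- Compound 2, `Nc1scc(CN2CCN(C3CCCCCC3)CC2)c1C(=O)c1ccc(Cl)cc1`: 2.9%
- Compound 3, `Nc1scc(CN2CCN(c3cccc4ccccc34)CC2)c1C(=O)c1ccc(Cl)cc1`: 8.7%

In a functional assay on CHO cells with adenosine receptor A1 (Homo sapiens) as the target, read by cAMP accumulation and immunoassay, with a stated time of 6 min, tested at 0.01 uM (on this read-out lower numbers stand for a stronger effect and higher numbers for a weaker effect at the one concentration tested), compound 3 gives 8.7%, the highest of the three numbers. Compound 2 lies nearest to it, within the scatter, while compound 1 lies furthest away, beyond the scatter, so among these three only the gap between compound 3 and compound 1 can be trusted as a real difference.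

Compound 4, `Nc1scc(CN2CCN(c3cc(Cl)ccc3Cl)CC2)c1C(=O)c1ccc(Cl)cc1`, has not yet been measured. It differs from compound 3 in one place: 2,5-dichlorophenyl in place of naphthalen-1-yl on an amine nitrogen in a ring. For the measured compounds named here, the only measured step that touches this same position is a number 5.8 percentage points higher from compound 2 to compound 3 (within the scatter), which exchanged a saturated ring for the naphthalen-1-yl group and stayed within the scatter. Going by the values given here, no measured pair swaps one aromatic group for another at this position, so the expectation for compound 4 rests on that single step alone. Since that step was within the scatter, the step from compound 3 to compound 4 is expected to be a number 3.7 percentage points lower from compound 3 to compound 4 (within the scatter), that is, no change beyond the scatter in either direction.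

Compound 4 is therefore estimated to give 5% in this assay, with a range from -10% to 20%.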

Compound 4, a percentage reported as activity, at one concentration (the size of the read-out at that concentration, not a potency): 13%
For compound 4 the middle estimate is 8 percentage points below the measured one; the measured number falls inside the stated range.
By their numbers in this assay, from the lowest: compound 1; then compounds 2, 3 and 4 (each within the scatter of the next, the first and the last beyond it).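

For the compounds shown here, this result gives the first comparison of two aromatic groups on the amine nitrogen of the six-membered ring. In this assay, the step is a number 4.3 percentage points higher from compound 3 to compound 4 (within the scatter), so replacing two fused aromatic rings with a single ring carrying two chlorines produces no readable difference. The saturated cycloheptyl group now gives the first readable contrast at this position, with a number 10.1 percentage points higher from compound 2 to compound 4 (beyond the scatter), and a higher number here stands for a weaker effect, although this step is only modest and the earlier step, a number 5.8 percentage points higher from compound 2 to compound 3 (within the scatter), did not clear the scatter, so the position responds to some changes but not clearly to all of them. No supporting measurement is available to explain these differences. The compounds shown leave open whether the result for compound 4 depends on its chlorines or on the phenyl ring itself, which a plain phenyl group or a phenyl group bearing one chlorine could help separate, and whether a piperidine ring or a carboxylic acid on the phenyl ring would be tolerated at this position.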